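The source may report more compounds than this note shows. Statements on the series, on what has been measured and on what is new or still open speak of the compounds shown alone.

Measured compounds in this series:

- compound 1, `O=C(CSc1nnnn1-c1cccc2ccccc12)N/N=C/c1cccc(Cl)c1`: 240000 nM
- compound 2, `Cc1cccc(/C=N/NC(=O)CSc2nnnn2-c2cccc3ccccc23)c1`: 269000 nM

Both values come from an ADME assay on MT4 cells (Homo sapiens) for cytotoxicity, read by MTT assay; on this read-out higher numbers stand for lower toxicity in this test and lower numbers for higher toxicity in this test. Compound 1 gives the lowest of the two numbers, with compound 2 nearest: the step of a 1.1-fold higher number from compound 1 to compound 2 (0.05 log units; within the scatter) lies within the scatter, so the two compounds cannot be told apart on this read-out. Within the data shown here, the one measured step replaces chloro with methyl on an aromatic carbon, and it left the number unchanged within the scatter.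

The unmeasured compound 3, `COc1ccc(/C=N/NC(=O)CSc2nnnn2-c2cccc3ccccc23)cc1OC`, departs from compound 1 by a larger change at the same part of the molecule: 3,4-dimethoxyphenyl in place of 3-chlorophenyl on a carbon with a double bond to nitrogen. Among the measured compounds shown here, no measured step covers the entry of two methoxy groups, so the only guide is the chloro-to-methyl step from compound 1 to compound 2, which bears on this position and was flat. On that basis no step beyond the scatter is expected for compound 3 in this assay, and the estimate is a step of a 1.0-fold higher number from compound 1 to compound 3 (0.02 log units; within the scatter). Compound 3 is therefore estimated at 250000 nM, within 120000 nM to 520000 nM.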

Compound 3, half-maximal cytotoxic concentration: 191000 nM
Estimate against measurement, compound 3: 1.3-fold (0.12 log units) above; low and high end bracket the measured number.
By their numbers in this assay, from the lowest: compounds 3, 1 and 2 (each within the scatter of the next).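

In this assay, 3,4-dimethoxyphenyl in place of 3-chlorophenyl gives a 1.3-fold lower number from compound 1 to compound 3 (0.10 log units; within the scatter), and the same group in place of 3-methylphenyl gives a 1.4-fold lower number from compound 2 to compound 3 (0.15 log units; within the scatter). The flat read-out at this position therefore extends beyond the single-atom-sized exchange of chloro for methyl: a group of 10 heavy atoms with 2 hydrogen-bond acceptors replaces groups without acceptors, and compounds 1, 2 and 3 still cannot be told apart. No evidence is available on why the number holds across these groups.

As far as these compounds go, all three compounds carry a substituted phenyl ring on the carbon with a double bond to nitrogen, so it remains open whether an amine or a carboxylic acid on that ring, or a longer alkyl chain in place of the ring, would move the number beyond the scatter. Every compound shown also keeps the core of compound 1, so how this read-out responds to a change in the core remains open as well.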